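From a Methylphenyl to a Methoxyphenyl Amine

The source may hold more compounds than are shown below. What is called first, only, known or untested is meant among the compounds shown, and "the series" means these compounds.

Compound 1 `CCCCCCCCCCCCCCNc1nc(SCc2ccc(C(F)(F)F)cc2)nc2ccccc12`; compound 2 `Cc1ccccc1Nc1nc(SCc2ccc(C(F)(F)F)cc2)nc2ccccc12`.

In a functional assay on HGC-27 cells (Homo sapiens) for cytotoxicity, read by MTT assay, with a stated time of 72 h (a higher number here means a weaker inhibitor, a lower number a stronger inhibitor), compound 1 reaches only > 50000 nM, which is a limit of the assay rather than a number. Going by the values given here, compound 2 gives 27500 nM in this assay, the only number among the values shown; the other value is the limit of > 50000 nM in this assay, at which 1 of the 2 values shown sits. Compound 3 `COc1ccc(Nc2nc(SCc3ccc(C(F)(F)F)cc3)nc3ccccc23)cc1` differs from compound 2 by 4-methoxyphenyl in place of 2-methylphenyl on a nitrogen on an aromatic ring. Among the compounds with values here, no step between measured compounds is available here, so a modest step in either direction, or none beyond the scatter, is expected in this assay. Compound 3 is expected to give 25000 nM, within 8000 nM to 50000 nM, a step of a 1.1-fold lower number from compound 2 to compound 3 (0.04 log units; within the scatter).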

Compound 3, half-maximal inhibitory concentration: 23500 nM
Beside the measured number, compound 3's estimate is 1.1-fold (0.03 log units) above it; the measured number falls inside the stated range.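

On a nitrogen on an aromatic ring, 4-methoxyphenyl in place of 2-methylphenyl gives a 1.2-fold lower number from compound 2 to compound 3 (0.07 log units; within the scatter) in this assay, so these two aryl groups cannot be told apart here. Going by these compounds alone, this is the first step that can be read at this position, and the oxygen of the entering group, a hydrogen-bond acceptor, does not separate the two compounds. Compound 1 carries a limit rather than a number, so its steps cannot be read: the limit of > 50000 nM in this assay, at which 1 of the 3 values shown sits.

Still open, going by these compounds, is whether a carboxylic acid or an amine on the aryl group, or a shorter alkyl chain on the nitrogen, would give a step beyond the scatter.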